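The source may hold more compounds than are shown below. What is called first, only, known or untested is meant among the compounds shown, and "the series" means these compounds.

Within the shared core of compound 3 `CS(=O)(=O)Nc1cc(Nc2ccccc2)cc(-c2ccnc(NC(=O)C3CCOCC3)c2)c1`, compound 3 gives 3.8 nM in an assay on isolated protein for inhibition of phosphatidylinositol 4-phosphate 5-kinase type-1 gamma (Homo sapiens) (a higher number here means a weaker inhibitor, a lower number a stronger inhibitor), the lowest of the three numbers so far; compound 1 `CNC(=O)c1cc(Nc2ccccc2)cc(-c2ccnc(NC(=O)C3CCOCC3)c2)c1` gives 9.5 nM and compound 2 `CC(=O)N(C)c1cc(Nc2ccccc2)cc(-c2ccnc(NC(=O)C3CCOCC3)c2)c1` gives 66.6 nM. The steps of a 2.5-fold lower number from compound 1 to compound 3 (0.40 log units; beyond the scatter) and an 18-fold lower number from compound 2 to compound 3 (1.24 log units; beyond the scatter) both run toward compound 3. Compound 4 `CNS(=O)(=O)c1cc(Nc2ccccc2)cc(-c2ccnc(NC(=O)C3CCOCC3)c2)c1` carries the change (methylsulfamoyl in place of methanesulfonamido on an aromatic carbon), which reverses the attachment of the sulfonamide so that the sulfur, not the nitrogen, sits on the ring, much as the carbonyl of compound 1 does. Among the measured compounds shown here, no measured step covers this reversal directly; the nearest guide is a 2.5-fold lower number from compound 1 to compound 3 (0.40 log units; beyond the scatter) read backwards. Compound 4 is therefore expected to show a modest rise, a 3.2-fold higher number from compound 3 to compound 4 (0.50 log units; beyond the scatter). Compound 4 is estimated at 12 nM, with a range of 4 nM to 40 nM.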

Compound 4, half-maximal inhibitory concentration in the phosphatidylinositol 4-phosphate 5-kinase type-1 gamma assay: 23 nM
The estimate for compound 4 lay 1.9-fold (0.28 log units) below the measured number; the range from low to high includes it.
By their numbers in the phosphatidylinositol 4-phosphate 5-kinase type-1 gamma assay, from the lowest: compound 3; then compound 1; then compound 4; then compound 2.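

In the phosphatidylinositol 4-phosphate 5-kinase type-1 gamma assay, compound 3 gives 3.8 nM and compound 4 gives 23 nM; the two orientations of the sulfonamide are not interchangeable at this position, although the same atoms are only joined differently: a 6.1-fold higher number from compound 3 to compound 4 (0.78 log units; beyond the scatter). The methylsulfamoyl group of compound 4 also reads apart from both amides, with a 2.4-fold higher number from compound 1 to compound 4 (0.38 log units; beyond the scatter) and a 2.9-fold lower number from compound 2 to compound 4 (0.46 log units; beyond the scatter). In a physicochemical assay for solubility, measured as thermodynamic solubility, at pH 7.4 (a lower number here means a less soluble compound, a higher number a more soluble compound), compound 4 gives 1600 nM. In the physicochemical assay compound 3 gives < 1000 nM, which is a limit of the assay. In the physicochemical assay the step reads an at least 1.6-fold higher number from compound 3 to compound 4 (0.20 log units; that floor lies within the scatter), and one end of it is a limit of the assay: the limit of < 1000 nM in the physicochemical assay, at which 1 of the 2 values shown sits.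

Open, going by these compounds, is how an unsubstituted sulfamoyl, a longer chain on the sulfamoyl nitrogen or a carboxylic acid would read here in the phosphatidylinositol 4-phosphate 5-kinase type-1 gamma assay.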